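The source may hold more compounds than are shown below. What is called first, only, known or untested is meant among the compounds shown, and "the series" means these compounds.

Compound 1 `COC(=O)C(F)(F)Nc1cc(CS(=O)(=O)/C=C/c2c(OC)cc(OC)cc2OC)ccc1OC`: 250 nM
Compound 2 `COC(=O)C(Nc1cc(CS(=O)(=O)/C=C/c2c(OC)cc(OC)cc2OC)ccc1OC)c1ccccc1`: 75 nM

Both compounds were tested in a functional assay on DU-145 cells (Homo sapiens) for cytotoxicity, read by trypan blue exclusion, with a stated time of 96 h; a lower number here means a stronger inhibitor, a higher number a weaker inhibitor. Compound 2 has the lower of the two numbers, making it the stronger inhibitor of this pair. Among the compounds with values here, the only measured step is a 3.3-fold lower number from compound 1 to compound 2 (0.52 log units; beyond the scatter). Compound 3 `COC(=O)C(Nc1cc(CS(=O)(=O)/C=C/c2c(OC)cc(OC)cc2OC)ccc1OC)c1ccc(Cl)cc1` is compound 2 with its phenyl turned into 4-chlorophenyl: chloro in place of hydrogen on an aromatic carbon. Within the data shown here, the measured step replaced a whole group on the nitrogen, so it bears only loosely on this smaller edit, and no measured compound carries a chloro. No direction can be drawn from these data, and no shift beyond the scatter is expected in this assay. The estimate is a 1.2-fold lower number from compound 2 to compound 3 (0.06 log units; within the scatter). For compound 3 the expected value is 65 nM, with an estimated range of 22 nM to 190 nM.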

Compound 3, half-maximal inhibitory concentration: 400 nM
Compound 3: the middle estimate sits 6.2-fold (0.79 log units) below what was measured; the measured number lies above the stated range.
By their numbers in this assay, from the lowest: compound 2; then compounds 1 and 3 (each within the scatter of the next).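

In this assay, adding one chloro to the phenyl of compound 2, para to a large group, gives a 5.3-fold higher number from compound 2 to compound 3 (0.73 log units; beyond the scatter), so this position responds clearly to a change of a single heavy atom. Within the data shown here, the edit also removes the gap that compound 2 held over compound 1, since the comparison of the two groups on the nitrogen now reads a 1.6-fold higher number from compound 1 to compound 3 (0.20 log units; within the scatter) and the choice between them no longer separates the compounds once the chloro is present. Nothing in the available data explains why the chloro raises the number.

A single substituent cannot show whether any group at this carbon would raise the number or whether the result is particular to chloro. An amine or a nitrile at the same place would help to settle that question.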